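From Fluoro to 4-Sulfamoylphenyl on the Shared Core

A few compounds are considered here, and "the series" means these few. Any claim that something is new, unique, unknown or untested is made for them only; others in the source may bear on it.

Compound 1 `N#Cc1ccc(F)cc1Cn1c(N2CCC[C@@H](N)C2)nc2c(-c3ccc(F)cc3)c[nH]c2c1=O`: 1.21 h
Compound 2 `N#Cc1ccc(F)cc1Cn1c(N2CCC[C@@H](N)C2)nc2cc[nH]c2c1=O`: > 1 h, a limit of the assay and not a number
Compound 3 `N#Cc1ccc(F)cc1Cn1c(N2CCC[C@@H](N)C2)nc2c(F)c[nH]c2c1=O`: 0.838 h

All three compounds were tested in an ADME assay on microsomes from liver (Rattus norvegicus) for metabolic stability, read by LC-MS, tested at 1 mM; on this read-out higher numbers stand for a longer-lived compound and lower numbers for a shorter-lived compound. Going by the values given here, only two exact numbers are available, and they lie close together: a 1.4-fold lower number from compound 1 to compound 3 (0.16 log units; within the scatter). Compound 3 therefore cannot be separated from compound 1 on these data.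

Compound 4 `N#Cc1ccc(F)cc1Cn1c(N2CCC[C@@H](N)C2)nc2c(-c3ccc(S(N)(=O)=O)cc3)c[nH]c2c1=O` has 4-sulfamoylphenyl in place of fluoro on an aromatic carbon of compound 3 (4-sulfamoylphenyl in place of fluoro on an aromatic carbon). Among the compounds with values here, no measured compound carries 4-sulfamoylphenyl. The closest guide is a swap at the same place between 4-fluorophenyl and fluoro: a 1.4-fold lower number from compound 1 to compound 3 (0.16 log units; within the scatter). The swap between hydrogen and fluoro adds only a floor: an at least 1.1-fold lower number from compound 2 to compound 3 (0.07 log units; that floor lies within the scatter). Neither comparison shows a step beyond the scatter, so no large shift is expected in this assay. The expected step is a 1.2-fold higher number from compound 3 to compound 4 (0.08 log units; within the scatter). For compound 4, the estimated value is 1 h, with an expected range of 0.5 h to 2 h.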

Compound 4, half-life: > 3.33 h
Compound 4 ended at the assay's limit (the forecaster's own chance of this, stated with the estimate: 20%); middle value at least 3.3-fold (0.52 log units) from the limit.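

At this carbon of the five-membered aromatic ring, this assay now shows a step beyond the scatter, which no earlier comparison gave: an at least 3.9-fold higher number from compound 3 to compound 4 (0.59 log units; beyond the scatter). The change on the phenyl ring also counts, since compound 1 carries that ring with fluoro on it: an at least 2.7-fold higher number from compound 1 to compound 4 (0.43 log units; beyond the scatter). Both steps are only floors, and the step from compound 2 to compound 4 cannot be read, because compound 4 carries a limit of the assay and not a number: the limit of > 3.33 h in this assay, at which 1 of the 4 values shown sits.

On these data alone, how long the half-life of compound 4 really is stays open. Also open, as far as these compounds go, is whether a carboxylic acid or an amine in place of the sulfamoyl group on the phenyl ring would give a step of the same direction.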